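Swapping the aryl group on a pyridazinone-type core

The compounds below may be only part of what the source reports. "The series", "measured", "known", "first", "only" and "open" are said of these compounds alone.

This account follows one structural change within a small set of compounds tested in a functional assay on HeLa cells (Homo sapiens) for antiproliferative activity, read by MTT assay, with a stated time of 72 h; on this read-out higher numbers stand for weaker inhibition and lower numbers for stronger inhibition. Compound 1, with the structure `CCCNC(=O)c1cc(Oc2ccc(NC(=O)c3nn(-c4ccc(Br)cc4F)c(=O)cc3C)cc2F)ccn1`, gives 53500 nM in this assay, which is the highest of the two numbers recorded. Its nearest neighbour is compound 2, `CCNC(=O)c1cc(Oc2ccc(NC(=O)c3nn(-c4cccc(C(F)(F)F)c4)c(=O)cc3C)cc2)ccn1`, which in this assay gives 10700 nM, a gap that lies beyond the usual scatter. A third member, compound 3 with the structure `CCNC(=O)c1cc(Oc2ccc(NC(=O)c3nn(-c4ccc(Br)cc4F)c(=O)cc3C)cc2)ccn1`, was reported in this assay as "not active" (no number reported), so no number stands for it. Among compounds 2 and 3 the shared aryl change is the same one that separates compound 1 from compound 4, and compound 2 carries the group that enters here, while compound 3 carries the group that leaves.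

Compound 4, `CCCNC(=O)c1cc(Oc2ccc(NC(=O)c3nn(-c4cccc(C(F)(F)F)c4)c(=O)cc3C)cc2F)ccn1`, is the compound not yet measured. It differs from compound 1 in one place: 3-(trifluoromethyl)phenyl in place of 4-bromo-2-fluorophenyl on an aromatic nitrogen. Going by the values given here, no step between measured compounds isolates this change, so the expectation rests on the values of compounds 2 and 3. Compound 4 is expected to show a moderate drop in this assay, a step of a 3.6-fold lower number from compound 1 to compound 4 (0.55 log units; beyond the scatter), and its estimated value is 15000 nM, within a range from 4000 nM to 50000 nM.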

Compound 4, half-maximal inhibitory concentration: 8000 nM
Compound 4: the middle estimate sits 1.9-fold (0.27 log units) above what was measured; measured number inside the range.
By their numbers in this assay, from the lowest: compounds 4 and 2 (each within the scatter of the next); then compound 1.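

In this assay, putting 3-(trifluoromethyl)phenyl in place of 4-bromo-2-fluorophenyl on the aromatic nitrogen gives a 6.7-fold lower number from compound 1 to compound 4 (0.83 log units; beyond the scatter), which shows that the aryl group at this position of the shared core can shift the read-out toward stronger inhibition. Going by these compounds alone, the earlier compounds could not put a size on this change: the only other pair carrying it, compound 3 and compound 2, has a "not active" report on one side, so its step cannot be read, and compound 1 with compound 4 is the first pair with a number on both sides. Nothing in the available data accounts for the size or direction of this step.

The swap removes bromine and fluorine and adds trifluoromethyl in a single move, so the compounds shown do not separate the contribution of each, and a plain phenyl group or a 4-bromophenyl group on the same nitrogen would be needed to do so. Going by these compounds, it also remains open whether a benzyl group or another non-aryl substituent at this position would be tolerated in this assay.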